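The compounds below may be only part of what the source reports. "The series", "measured", "known", "first", "only" and "open" are said of these compounds alone.

Measured so far in an ADME assay on MT4 cells (Homo sapiens) for cytotoxicity, read by MTT assay; on this read-out lower numbers stand for higher toxicity in this test and higher numbers for lower toxicity in this test:
compound 1 `Cc1ccc(NC(=O)CSc2nccn2-c2cccc3ccccc23)c(Br)c1`: 29400 nM
compound 2 `Cc1ccccc1NC(=O)CSc1nccn1-c1ccc(Cl)cc1`: 160000 nM
compound 3 `O=C(CSc1nccn1-c1ccc(Cl)cc1)Nc1ccccc1Br`: a limit of the assay, > 300000 nM

Among the two numbers shown, compound 1 has the lowest; compound 2 stands nearest, with a higher number beyond the scatter. The value for compound 3 is a limit only (the limit of > 300000 nM in this assay, at which 1 of the 3 values shown sits).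

Compound 4 `Cc1ccccc1NC(=O)CSc1nccn1-c1cccc2ccccc12` is not yet measured. It differs from compound 1 by 2-methylphenyl in place of 2-bromo-4-methylphenyl on an amide-type nitrogen, so the naphthyl-bearing core of compound 1 is kept and only the anilide part changes.

Among the measured compounds shown here, one measured step bears on this change, though in the opposite sense and on a different core: an at least 1.8-fold higher number from compound 2 to compound 3 (0.27 log units; that floor lies within the scatter). There a bromo entering in place of methyl raised the number, but only to a floor that lies within the scatter, so the direction is not secured. For compound 4 the bromo leaves while a methyl remains, and the core shared with compound 1 is the one that gave the lowest number shown. The expected step is therefore small, a 1.3-fold lower number from compound 1 to compound 4 (0.13 log units; within the scatter), within the scatter, with a slight lean toward a lower number.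

Compound 4 is expected to give about 22000 nM in this assay, estimated between 7000 nM and 70000 nM.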

Compound 4, half-maximal cytotoxic concentration: 34600 nM
For compound 4 the middle estimate is 1.6-fold (0.20 log units) below the measured one; the measured number falls inside the stated range.
By their numbers in this assay, from the lowest: compounds 1 and 4 (each within the scatter of the next); then compound 2. At a limit, above all of these: compound 3.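

In this assay the first step within the core of compound 1 reads a 1.2-fold higher number from compound 1 to compound 4 (0.07 log units; within the scatter), so on this core the 2-bromo-4-methylphenyl and the 2-methylphenyl on the amide-type nitrogen give numbers within the scatter of each other. Nothing shown gives a reason for this result. Among the compounds shown here, compound 2 and compound 4 share the 2-methylphenyl and differ in one other place, which gives the first such comparison with the anilide part held constant: compound 2 gives 160000 nM and compound 4 gives 34600 nM.

As far as these compounds go, the change from compound 1 to compound 4 takes out the bromo and the 4-methyl together, so the separate contribution of each on this core stays open, as does the outcome with an amine or a carboxylic acid on the aromatic ring of the anilide. The earlier bromo-for-methyl step, an at least 1.8-fold higher number from compound 2 to compound 3 (0.27 log units; that floor lies within the scatter), has no definite size because compound 3 is recorded only as a limit: the limit of > 300000 nM in this assay, at which 1 of the 4 values shown sits.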